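Swapping Phenyl for Furan-3-yl on a Weakly Active Core

The source may hold more compounds than are shown below. What is called first, only, known or untested is meant among the compounds shown, and "the series" means these compounds.

Three close relatives of one shared core have been tested in a functional assay on K562 cells (Homo sapiens), read by MTT assay, with a stated time of 72 h; a lower number here means a stronger inhibitor, a higher number a weaker inhibitor. Compound 1 `Cc1nc(N)c2c(-c3ccccc3)cn([C@@H]3O[C@H](CO)[C@@H](O)[C@H]3O)c2n1` gives only a limit of the assay, > 20000 nM. Compound 2 `Nc1nc(N)c2c(-c3ccccc3)cn([C@@H]3O[C@H](CO)[C@@H](O)[C@H]3O)c2n1` likewise gives only a limit, > 20000 nM. Compound 3 `Cc1nc(N)c2c(-c3ccsc3)cn([C@@H]3O[C@H](CO)[C@@H](O)[C@H]3O)c2n1` also gives only a limit, > 20000 nM. Because all three values sit at the limit of > 20000 nM in this assay, at which 3 of the 3 values shown sit, neither measured step can be read: a step that the two limits leave unreadable from compound 1 to compound 2 and a step that the two limits leave unreadable from compound 1 to compound 3. Compound 2 therefore stands at the limit of this assay together with its two companions, and nothing separates them.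

Compound 4 `Nc1nc(N)c2c(-c3ccoc3)cn([C@@H]3O[C@H](CO)[C@@H](O)[C@H]3O)c2n1` differs from compound 2 in one place: furan-3-yl in place of phenyl on an aromatic carbon. The nearest measured step, a step that the two limits leave unreadable from compound 1 to compound 3, also exchanges phenyl for a five-membered aromatic ring and left no readable size. For the measured compounds named here, no measured step shows any exchange at this position raising inhibition, so the estimated step that the limit leaves unreadable from compound 2 to compound 4 is expected to be none beyond the scatter. Compound 4 is therefore expected to give 25000 nM, within 8000 nM to 80000 nM, most probably reported again only as a limit.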

Compound 4, half-maximal inhibitory concentration: > 20000 nM
Compound 4 was reported as a limit (the forecaster's own chance of this, stated with the estimate: 85%); the middle value is on the limit's open side.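

No size can be read for the exchange of phenyl for furan-3-yl from compound 2 to compound 4, since both compounds give only a limit, as do the other two: the limit of > 20000 nM in this assay, at which 4 of the 4 values shown sit.

As far as these compounds go, whether any change to the shared core can give a measurable inhibition value remains open.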